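Amine to ether on the shared core

The compounds below may be only part of what the source reports. "The series", "measured", "known", "first", "only" and "open" are said of these compounds alone.

Measured values in a functional assay on HeLa cells (Homo sapiens) for antiproliferative activity, read by WST assay, with a stated time of 24 h; a lower number here means a stronger inhibitor, a higher number a weaker inhibitor
Compound 1 `C=C[C@]1(C)CC[C@@H](C(=C)CNC(C)(C)C)C[C@H]1C(=C)C` gives 25400 nM
Compound 2 `C=C[C@]1(C)CC[C@@H](C(=C)COCC)C[C@H]1C(=C)C` gives 106000 nM
Compound 3 `C=C[C@]1(C)CC[C@@H](C(=C)CNCCCC)C[C@H]1C(=C)C` gives 10800 nM

Compound 3 has the lowest number of the three, and its steps to both others lie beyond the scatter. Compound 4 `C=C[C@]1(C)CC[C@@H](C(=C)COCCOC)C[C@H]1C(=C)C` carries 2-methoxyethoxy in place of butylamino on a saturated chain carbon bound to a double-bonded chain carbon, a difference that reads 2-methoxyethoxy in place of butylamino on a saturated chain carbon bound to a double-bonded chain carbon and leaves the shared core unchanged.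

Among the compounds with values here, two measured steps bear on this exchange. The closest is a 9.8-fold lower number from compound 2 to compound 3 (0.99 log units; beyond the scatter) with butylamino in place of ethoxy, which runs the opposite way. The other is a 4.2-fold higher number from compound 1 to compound 2 (0.62 log units; beyond the scatter) with ethoxy in place of (tert-butyl)amino, which runs the same way but is smaller. Within the data shown here, no measured compound shows what the added methoxy does to the number, so compound 2 at 106000 nM is the only guide among the ethers. A clear rise beyond the scatter is therefore expected, and the estimated step is an 8.3-fold higher number from compound 3 to compound 4 (0.92 log units; beyond the scatter) in this assay on this reasoning. Compound 4 is estimated at 90000 nM with 40000 nM to 200000 nM as its expected range.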

Compound 4, half-maximal inhibitory concentration: 238000 nM
Beside the measured number, compound 4's estimate is 2.6-fold (0.42 log units) below it; the measured number lies above the stated range.
By their numbers in this assay, from the lowest: compound 3; then compound 1; then compound 2; then compound 4.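

In this assay, within the data shown here, 2-methoxyethoxy in place of butylamino on a saturated chain carbon bound to a double-bonded chain carbon gives a 22-fold higher number from compound 3 to compound 4 (1.34 log units; beyond the scatter), and in place of (tert-butyl)amino it gives a 9.4-fold higher number from compound 1 to compound 4 (0.97 log units; beyond the scatter), so compound 4 is the weakest of the four and both ethers stand at higher numbers than both amines, with no compound going against this. The ether itself is also sensitive to change, since methoxy in place of hydrogen on its chain gives a 2.2-fold higher number from compound 2 to compound 4 (0.35 log units; beyond the scatter) and moves the number further from the amines. Nothing available accounts for these steps.

A butoxy group at this place would show whether the amine-to-ether difference holds at the chain length of butylamino without the methoxy oxygen. On these data alone, how a tertiary amine such as dimethylamino, or a carboxylic acid, would read here remains open.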